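This account rests on a few compounds, and the source may have more. Where it says the series, first, only, none or still open, it means among the compounds named here.

Measured compounds:
compound 1 `Nc1ccc(C#CCCN2CCC(O)(Cc3ccccc3)CC2)cc1`, 63000 nM in an assay on isolated protein for binding affinity to Adrenergic receptor alpha-1 (Rattus norvegicus), read by radioligand binding; a higher number here means a weaker inhibitor, a lower number a stronger inhibitor
compound 2 `Nc1ccc(C#CCCN2CCC(Cc3ccccc3)CC2)cc1`, 1000 nM in this assay

Compound 1 stands at the higher of the two numbers in this assay; its nearest neighbour is compound 2, and the step of a 63-fold lower number from compound 1 to compound 2 (1.80 log units; beyond the scatter) is large and lies beyond the scatter. Among the compounds with values here, that step exchanges the hydroxy on a saturated ring carbon for hydrogen, and it is the only measured step.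

Compound 3 `Cc1ccc(CC2(O)CCN(CCC#Cc3ccc(N)cc3)CC2)cc1` keeps the hydroxy of compound 1 and differs from it only by methyl in place of hydrogen on an aromatic carbon. Within the data shown here, no measured pair changes the benzyl ring in this way, so the single known step, from the hydroxy to hydrogen, does not bear directly on it; it only shows that the hydroxy-bearing branch of the series sits at weak binding. A methyl on the aromatic ring is expected to leave that branch roughly where it is, with at most a modest shift in either direction; the expected step of a 1.6-fold lower number from compound 1 to compound 3 (0.20 log units; within the scatter) is small. Compound 3 is therefore estimated at 40000 nM in this assay, within a range from 10000 nM to 160000 nM.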

Compound 3, half-maximal inhibitory concentration: 85000 nM
Compound 3: middle estimate off by 2.1-fold (0.33 log units), on the low side; measured number inside the range.
By their numbers in this assay, from the lowest: compound 2; then compounds 1 and 3 (each within the scatter of the next).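

Methyl in place of hydrogen on an aromatic carbon, para to a large group, gives a 1.3-fold higher number from compound 1 to compound 3 (0.13 log units; within the scatter) in this assay, the first measured change on the benzyl ring rather than at the hydroxy-bearing ring carbon. Compound 1 and compound 3 therefore read as one level, and going from benzyl to 4-methylbenzyl makes no difference that can be separated from the scatter while the hydroxy stays in place; this holds for this one pair, at the weak end of the series, and for this one small group. Nothing available bears on why the methyl leaves the reading within the scatter.

The compounds shown leave open whether the same methyl would also make no readable difference in the branch of compound 2, which lacks the hydroxy and stands at a much lower number, since a flat step in a weakly binding compound need not carry over to a stronger one. They also leave open how the same aromatic carbon would answer to a group other than methyl, such as methoxy, chlorine or a carboxylic acid, or to a methyl placed elsewhere on the ring.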